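Series notes: expected cytotoxicity of compound 3

The compounds below may be only part of what the source reports. "The series", "measured", "known", "first", "only" and "open" are said of these compounds alone.

compound 1, `Cc1nc(Nc2cccc(Cl)c2)sc1C(=O)/C=C/c1ccccc1`: a limit, > 25000 nM
compound 2, `Cc1nc(Nc2cccc(Cl)c2)sc1C(=O)/C=C/c1ccc(Cl)cc1`: a limit, > 25000 nM

In a functional assay on Bel-7402 cells (Homo sapiens) for cytotoxicity, read by MTT assay (a lower number here means a stronger inhibitor, a higher number a weaker inhibitor), compound 1 gives only a limit, > 25000 nM. Compound 2 likewise returns a limit, > 25000 nM. The step from compound 1 to compound 2, a step that the two limits leave unreadable from compound 1 to compound 2, cannot be read; both values sit at the limit of > 25000 nM in this assay, at which 2 of the 2 values shown sit. Compound 3, `Cc1ccccc1Nc1nc(C)c(C(=O)/C=C/c2ccccc2)s1`, differs from compound 1 by 2-methylphenyl in place of 3-chlorophenyl on a nitrogen on an aromatic ring. Going by the values given here, no measured step bears on this exchange; the one measured step is unreadable. For compound 3 the expected step in this assay is a step that the limit leaves unreadable from compound 1 to compound 3, with no direction readable from the data. Compound 3 is estimated at 30000 nM, range 8000 nM to 120000 nM, most likely again a limit.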

Compound 3, half-maximal inhibitory concentration: > 25000 nM
Compound 3 was reported as a limit; the forecaster's own chance of this, stated with the estimate: 70%; the middle value is on the limit's open side.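

Compound 1 and compound 3 are both limits in this assay, so no step between them can be read: the limit of > 25000 nM in this assay, at which 3 of the 3 values shown sit.

As far as these compounds go, whether any exchange on the shared core gives a readable value in this assay remains open.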